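Amide-nitrogen substituent swap on the pyridine carboxamide series

The source may hold more compounds than are shown below. What is called first, only, known or untested is meant among the compounds shown, and "the series" means these compounds.

Measured compounds:
compound 1, `Cn1ccc2ccc(-c3cc(Nc4cnccc4C(=O)NCc4cncnc4)cc4nccnc34)cc21`, gives 49500 nM in an assay on lysate for inhibition of 6-phosphofructo-2-kinase/fructose-2,6-bisphosphatase 3 (Homo sapiens), with stated times of 0.5 min and 45 min; a lower number here means a stronger inhibitor, a higher number a weaker inhibitor.
compound 2, `CN1CC(NC(=O)c2ccncc2Nc2cc(-c3ccc4ccn(C)c4c3)c3nccnc3c2)CCC1=O`, gives 96500 nM in this assay.

Compound 2 sits at the upper end of the two numbers in this assay, yet compound 1 stands within the scatter of it: a 1.9-fold higher number from compound 1 to compound 2 (0.29 log units; within the scatter). Both compounds are weak in this assay.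

Compound 3, `CC(=O)N1CC(CNC(=O)c2ccncc2Nc2cc(-c3ccc4ccn(C)c4c3)c3nccnc3c2)C1`, differs from compound 2 in one place: (1-acetylazetidin-3-yl)methyl in place of 1-methyl-6-oxopiperidin-3-yl on an amide-type nitrogen. Going by the values given here, the only measured step that bears on it is the one at the same amide-type nitrogen, from compound 1 to compound 2, and that step stayed within the scatter. Nothing measured here separates a six-membered ring carrying an oxo group from a four-membered ring carrying an acetyl group at this nitrogen, so the data give no ground for expecting a step beyond the scatter in either direction in this assay.

Compound 3 is therefore expected to stay close to compound 2, with an estimated step of a 1.1-fold lower number from compound 2 to compound 3 (0.03 log units; within the scatter). The estimate for compound 3 in this assay is 90000 nM, with a range from 30000 nM to 270000 nM.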

Compound 3, half-maximal inhibitory concentration: > 100000 nM
Compound 3: only a limit was reported; the forecaster's own chance of this, stated with the estimate: 30%; middle value at least 1.1-fold (0.04 log units) away from the limit.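

Compound 3 adds a third substituent on the amide-type nitrogen and gives only a limit, not a number: the limit of > 100000 nM in this assay, at which 1 of the 3 values shown sits. Read as floors, the new steps are an at least 1.0-fold higher number from compound 2 to compound 3 (0.01 log units; that floor lies within the scatter) and an at least 2.0-fold higher number from compound 1 to compound 3 (0.30 log units; that floor lies within the scatter), so neither step can be placed beyond the scatter. What this adds is that (1-acetylazetidin-3-yl)methyl, with its four-membered ring, also fails to bring a strong number at this position in this assay, so the three substituents shown, with a pyrimidine, a six-membered oxo ring or a four-membered acetyl ring, all leave the series weak.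

Going by these compounds, how far compound 3 lies past its limit stays open, and with it whether exchanging 1-methyl-6-oxopiperidin-3-yl for (1-acetylazetidin-3-yl)methyl changes anything at all. Also open, on these data alone, is how a plain methyl group, or a carboxylic acid or a primary amine on a short chain, would read on this amide-type nitrogen in this assay.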